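The source may report more compounds than this note shows. Statements on the series, on what has been measured and on what is new or still open speak of the compounds shown alone.

Measured in an ADME assay on microsomes from liver (Homo sapiens) for metabolic stability; on this read-out lower numbers stand for slow clearance and higher numbers for fast clearance:
- Compound 1 `C[C@H](NC(=O)Cn1nnc2ccccc2c1=O)c1ccc(Cl)cc1`: < 9.9 mL/min/kg
- Compound 2 `Cc1ccc([C@H](C)NC(=O)Cn2nnc3ccccc3c2=O)c(C)c1`: 33 mL/min/kg

In this assay compound 1 gives < 9.9 mL/min/kg, which is a limit of the assay and not a number. It stands at the limit of < 9.9 mL/min/kg in this assay, at which 1 of the 2 values shown sits. Compound 3 `C[C@H](NC(=O)Cn1nnc2ccccc2c1=O)c1ccc(OC(F)F)cc1` has not yet been measured. It carries difluoromethoxy in place of chloro on an aromatic carbon, para to a large group: difluoromethoxy in place of chloro on an aromatic carbon.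

Going by the values given here, one measured step bears on this change. It also removes the chloro at that place. With 2,4-dimethylphenyl in place of 4-chlorophenyl, it is an at least 3.3-fold higher number from compound 1 to compound 2 (0.52 log units; beyond the scatter), which lies beyond the scatter. That single step involves a different entering group, so it is only a loose guide. A modest rise in this assay is therefore expected, smaller than that measured step, and it may not clear the scatter. The estimated step is an at least 1.4-fold higher number from compound 1 to compound 3 (0.15 log units; that floor lies within the scatter). Compound 3 is expected at 14 mL/min/kg, with an estimated range of 7 mL/min/kg to 30 mL/min/kg.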

Compound 3, clearance: < 9.9 mL/min/kg
Compound 3: a limit, no number; the forecaster's own chance of this, stated with the estimate: 35%; at least 1.4-fold (0.15 log units) between middle value and limit.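

In this assay compound 3 gives < 9.9 mL/min/kg, which is a limit of the assay and not a number. Compound 1 also stands at a limit, so no step can be read between compound 1 and compound 3: the limit of < 9.9 mL/min/kg in this assay, at which 2 of the 3 values shown sit. The compounds shown leave open whether difluoromethoxy in place of chloro changes clearance at all.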